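Thioether acid to succinate half-ester on a shared core

The source may hold more compounds than are shown below. What is called first, only, known or untested is meant among the compounds shown, and "the series" means these compounds.

Compound 1, `CC(C)c1cccc(C(C)C)c1OC(=O)COC(C(=O)O)C(=O)O`: "not active" (no number reported)
Compound 2, `CC(C)c1cccc(C(C)C)c1OC(=O)CSCC(=O)O`: 190 mg/kg

In a functional assay on the whole organism (strain Kunming) with Mus musculus as the target (on this read-out lower numbers stand for an effect already at smaller amounts and higher numbers for an effect only at larger amounts of compound), compound 2 gives 190 mg/kg. Compound 1 is reported in this assay only as "not active" (no number reported), without a number, so compound 2 holds the only figure shown. Compound 3, `CC(C)c1cccc(C(C)C)c1OC(=O)COC(=O)CCC(=O)O`, has not yet been measured; it differs from compound 2 by ((2-carboxyethyl)carbonyl)oxy in place of (carboxymethyl)sulfanyl on a saturated chain carbon bound to a carbonyl carbon. Among the compounds with values here, no step between measured compounds exists to guide the expectation, and the change is expected to shift this assay by no more than the usual scatter. For compound 3 the estimated value is 220 mg/kg, with a range from 90 mg/kg to 550 mg/kg. The step this expectation means is a 1.2-fold higher number from compound 2 to compound 3 (0.06 log units; within the scatter).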

Compound 3, dose for half-maximal effect: 73.1 mg/kg
Beside the measured number, compound 3's estimate is 3.0-fold (0.48 log units) above it, and the stated range ends above it.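

In this assay, this place on a saturated chain carbon bound to a carbonyl carbon accepts a larger group: ((2-carboxyethyl)carbonyl)oxy in place of (carboxymethyl)sulfanyl gives a 2.6-fold lower number from compound 2 to compound 3 (0.41 log units; beyond the scatter) and so a modest gain. The sulfur is therefore not needed for an effect on this shared core. Nothing shown gives a reason for this step.

Which part of the change matters stays open, whether the lost sulfur, the added carbonyl or the longer chain. Whether an amide in this place would serve as well is also unknown.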